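A single chlorophenyl swap on compound 1

The compounds below may be only part of what the source reports. "The series", "measured", "known", "first", "only" and "open" are said of these compounds alone.

Compound 1 `CC(C)c1ccc(Nc2ccc3c(OCCCN4CCN(C)CC4)cccc3n2)cc1`: 3280 nM
Compound 2 `CN1CCN(CCCOc2cccc3nc(Nc4cc(Cl)cc(Cl)c4)ccc23)CC1`: 1720 nM

For the measured compounds named here, in a functional assay on U-251 cells (Homo sapiens) for inhibition, read by sulforhodamine B assay, with a stated time of 48 h (a higher number here means a weaker inhibitor of growth, a lower number a stronger inhibitor of growth), compound 1 gives 3280 nM and stands within the scatter of compound 2, the only other compound measured so far. Compound 3 `CN1CCN(CCCOc2cccc3nc(Nc4cccc(Cl)c4)ccc23)CC1` has not yet been measured. It carries 3-chlorophenyl in place of 4-isopropylphenyl on a nitrogen on an aromatic ring. Going by the values given here, one measured step bears on this change, since compound 2 replaces the same group in the same place with 3,5-dichlorophenyl. That step shows a 1.9-fold lower number from compound 1 to compound 2 (0.28 log units; within the scatter) and is small. Among the compounds with values here, with only this evidence, no shift beyond the scatter is expected in this assay, though a slightly lower number would fit. The estimated step is a 1.4-fold lower number from compound 1 to compound 3 (0.15 log units; within the scatter) and stays small. For compound 3 the expected value is 2300 nM, with an estimated range of 1100 nM to 4600 nM.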

Compound 3, concentration for 50% growth inhibition: 1890 nM
Estimate against measurement, compound 3: 1.2-fold (0.09 log units) above; low and high end bracket the measured number.
By their numbers in this assay, from the lowest: compounds 2, 3 and 1 (each within the scatter of the next).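

In this assay, the step to 3-chlorophenyl on this nitrogen is a 1.7-fold lower number from compound 1 to compound 3 (0.24 log units; within the scatter) and adds a second replacement of 4-isopropylphenyl that stays within the scatter, as 3,5-dichlorophenyl did in compound 2. For the compounds shown here, for the first time, one chloro can also be set against two: hydrogen in place of chloro on an aromatic carbon gives a 1.1-fold higher number from compound 2 to compound 3 (0.04 log units; within the scatter) and so makes no difference beyond the scatter between these two compounds. No measurement shown here accounts for these small steps.

From the compounds shown here alone, whether a ring other than phenyl on this nitrogen, such as pyridine or cyclohexyl, or an amine or carboxylic acid on the phenyl ring, would move the number beyond the scatter remains open. The compounds also leave open what a longer chain in place of the side chain on the shared core would do.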